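The source may report more compounds than this note shows. Statements on the series, on what has been measured and on what is new or still open speak of the compounds shown alone.

Among the measured compounds shown here, compound 2 `C#CCO/N=C/c1c(N)ncnc1Oc1ccc(NC(=O)C2(C(=O)Nc3ccc(F)cc3)CC2)cc1F` gives 3.34 in a physicochemical assay for lipophilicity, using the shake flask method (on this read-out higher numbers stand for higher lipophilicity and lower numbers for lower lipophilicity), the highest of the two numbers so far; its nearest neighbour, compound 1 `Nc1ncnc(Oc2ccc(NC(=O)C3(C(=O)Nc4ccc(F)cc4)CC3)cc2F)c1/C=N/OCCCO`, gives 2.67. For the measured compounds named here, the single measured step, a number 0.67 log units higher from compound 1 to compound 2 (beyond the scatter), came from ethynyl in place of 2-hydroxyethyl on a saturated chain carbon bound to an oxygen. Compound 3 `CC(C)(C)OC(=O)N/N=C/c1c(N)ncnc1Oc1ccc(NC(=O)C2(C(=O)Nc3ccc(F)cc3)CC2)cc1F` differs from compound 2 by (tert-butoxycarbonyl)amino in place of propargyloxy on a double-bonded nitrogen. Going by the values given here, the measured step bears only loosely on this exchange, since the group that leaves here is the propargyloxy that entered there, while what now enters is of a different kind, and no measured step shows such a swap directly. A modest rise in this assay is nonetheless expected for compound 3, with a number 0.26 log units higher from compound 2 to compound 3 (within the scatter) as the estimated step. Compound 3 is therefore estimated at 3.6, within a range of 3 to 4.2.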

Compound 3, partition coefficient: 3.7
Compound 3: middle estimate off by 0.10 log units, on the low side; the measured number falls inside the stated range.
By their numbers in this assay, from the lowest: compound 1; then compound 2; then compound 3.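

In this assay, (tert-butoxycarbonyl)amino in place of propargyloxy on the double-bonded nitrogen gives a number 0.36 log units higher from compound 2 to compound 3 (beyond the scatter) and so extends the upward trend beyond compound 2, even though the entering group carries a hydrogen-bond donor that propargyloxy lacks. Measured against 3-hydroxypropoxy at the same place, the exchange gives a number 1.03 log units higher from compound 1 to compound 3 (beyond the scatter) and opens a large gap, where the earlier step at this place was only modest. Nothing on hand explains either rise. The compounds shown leave open how an amine, a carboxylic acid or a longer chain on the double-bonded nitrogen would read in this assay and where each would fall among these three compounds. They also do not separate the contribution of the tert-butyl part from that of the rest of the entering group.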